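The compounds below may be only part of what the source reports. "The series", "measured", "known", "first", "only" and "open" are said of these compounds alone.

Three compounds of a shared core have been examined in an ADME assay on PC-3 cells (Homo sapiens) for cytotoxicity, read by WST assay, tested at 100 uM; a higher number here means more inhibition at the concentration tested (going by the name of the read-out), a lower number less inhibition. Compound 1 `O=C(Nc1ccc(Cl)cn1)C1CCCN(C(=O)c2cc(C(F)(F)F)cc(C(F)(F)F)c2)C1` gives 0% there. Compound 2 `O=C(Nc1cccc(Cc2ccccc2)c1)C1CCCN(C(=O)c2cccc(-c3ccco3)c2)C1` gives 0%, level with compound 1 at the digits reported, and the two together sit at the bottom of the three numbers. Compound 3 `O=C(Nc1ccc(Cl)cc1)C1CCCN(C(=O)c2ccc(-c3ccco3)cc2)C1` gives 6%, a value that lies within the scatter of compound 2. Among the compounds with values here, none of these three differ from one another in a single place, so no measured step is available to guide a forecast.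

Compound 4 `O=C(Nc1cccc(Oc2ccccc2)c1)C1CCCN(C(=O)c2cccc(-c3ccco3)c2)C1` differs from compound 2 in one place: phenoxy in place of benzyl on an aromatic carbon. Since all three measured compounds sit near the floor of this assay, compound 4 is expected to stay there too, with a step of a number 3 percentage points higher from compound 2 to compound 4 (within the scatter) that is none beyond the scatter. Compound 4 is accordingly estimated at 3%, within a range of 0% to 15%.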

Compound 4, a percentage reported as inhibition, at one concentration (the size of the read-out at that concentration, not a potency): 0%
Compound 4: middle estimate off by 3 percentage points, on the high side; the measured number falls inside the stated range.
By their numbers in this assay, from the lowest: compounds 1, 2, 4 and 3 (each within the scatter of the next).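

Phenoxy in place of benzyl on an aromatic carbon, meta to a large group, gives no change at the digits printed from compound 2 to compound 4 (within the scatter) in this assay, the first single-place step available in this series. The exchange brings in one hydrogen-bond acceptor, yet at this position it produces no readable shift in the inhibition. Nothing available explains this result. From the compounds shown here alone, it remains open whether an amine, a carboxylic acid or a longer chain on this same carbon would lift the number clear of the scatter. Whether the furan-bearing half responds to change also stays unresolved.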